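A new group on the carbonyl of compound 3

The compounds below may be only part of what the source reports. "The series", "measured", "known", "first", "only" and "open" are said of these compounds alone.

In a functional assay on Shh Light II cells (Mus musculus) for inhibition, read by a luciferase reporter (on this read-out lower numbers stand for stronger inhibition and higher numbers for weaker inhibition), compound 3 (`O=C(Nc1ccccc1Cl)N1CCC(c2nc(-c3ccc4ccccc4n3)no2)CC1`) gives 510 nM, the middle of three values. Compound 1 (`C[C@@H]1C[C@H](c2nc(-c3ccc4ccccc4n3)no2)CCN1C(=O)Nc1ccccc1Cl`) gives 2400 nM, and compound 2 (`O=C(NC1CCCCC1)N1CCN(c2nc(-c3ccc4ccccc4n3)no2)CC1`) gives 53 nM. Compound 4 (`O=C(CC1CCCCCC1)N1CCC(c2nc(-c3ccc4ccccc4n3)no2)CC1`) carries cycloheptylmethyl in place of (2-chlorophenyl)amino on a carbonyl carbon. Among the compounds with values here, the only measured step, a 4.7-fold lower number from compound 1 to compound 3 (0.67 log units; beyond the scatter), is modest and concerns a different change, so it bears on this one only loosely. Compound 2, which lacks the (2-chlorophenyl)amino group, gives 53 nM, but it differs from compound 3 in more than that group. A modest move to a lower number is therefore expected in this assay, with a 3.0-fold lower number from compound 3 to compound 4 (0.48 log units; beyond the scatter) as the estimated step. The estimate for compound 4 is 170 nM, with an expected range of 40 nM to 700 nM.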

Compound 4, half-maximal inhibitory concentration: 840 nM
The estimate for compound 4 lay 4.9-fold (0.69 log units) below the measured number, and the stated range ends below it.
By their numbers in this assay, from the lowest: compound 2; then compounds 3 and 4 (each within the scatter of the next); then compound 1.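

In this assay, cycloheptylmethyl in place of (2-chlorophenyl)amino on a carbonyl carbon gives a 1.6-fold higher number from compound 3 to compound 4 (0.22 log units; within the scatter) and so leaves the read-out within the scatter. Within the data shown here, at this position, then, the six-membered aromatic ring, the chlorine and the hydrogen-bond donor can all leave together with no change beyond the scatter, which the earlier compounds did not show. No measured evidence here accounts for this result. The compounds shown leave open how cycloheptylamino, which would keep the nitrogen with the seven-membered ring, would read on this carbonyl carbon. Phenylamino, without the chlorine, remains equally open.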